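The source may report more compounds than this note shows. Statements on the series, on what has been measured and on what is new or still open speak of the compounds shown alone.

Measured in an in vitro ADME assay on microsomes from liver (Homo sapiens) for metabolic stability; a lower number here means that the compound disappears faster, a higher number that the compound lasts longer:
- Compound 1 `C[C@@H](c1ccc(Cl)cc1)N1Cc2cncn2C(CC2(C)COC2)S1(=O)=O`: 1.27 h
- Compound 2 `CC(C)CC1n2cncc2CN(C2CC2)S1(=O)=O`: > 6.75 h, a limit of the assay and not a number

Among the measured compounds shown here, compound 1 gives the only true number, 1.27 h. Compound 2 lasts longer than compound 1.

Compound 3 `CC(C)CC1n2cncc2CN([C@@H](C)c2ccc(Cl)cc2)S1(=O)=O` is compound 1 with a single change isopropyl in place of 3-methyloxetan-3-yl on a saturated chain carbon bound to a saturated ring carbon. Cut one bond further out, this reads (3-methyloxetan-3-yl)methyl to isobutyl. Compound 2 also carries isobutyl, but it differs from compound 3 elsewhere. The limit of compound 2, > 6.75 h, sets no size for this change. For the measured compounds named here, with no measured step as a guide, the expected step of a 1.3-fold lower number from compound 1 to compound 3 (0.10 log units; within the scatter) in this assay stays within the usual scatter, leaning slightly shorter. For compound 3 the estimated half-life is 1 h, with a range from 0.4 h to 2.5 h.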

Compound 3, half-life: 0.1 h
Estimate against measurement, compound 3: 10-fold (1.00 log units) above, outside the stated range (below it).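

In this assay, the group on this saturated chain carbon bound to a saturated ring carbon proves to matter: isopropyl in place of 3-methyloxetan-3-yl gives a 13-fold lower number from compound 1 to compound 3 (1.10 log units; beyond the scatter) and that step lies beyond the usual scatter. The two compounds differ in this one place, so the shorter half-life goes with the loss of the four-membered non-aromatic ring and its hydrogen-bond acceptor, although the data cannot say which of these counts. Nothing measured here gives a reason for the size of the step. Compound 2 also carries isobutyl and gives > 6.75 h as a limit of the assay and not a number, so its step to compound 3 cannot be read. Still open, from the compounds shown here alone, is where a cyclobutyl group, a morpholine or a longer ether chain at this place would fall.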